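Moving one trifluoromethyl group on the weakest compound

This account rests on a few compounds, and the source may have more. Where it says the series, first, only, none or still open, it means among the compounds named here.

In a functional assay on LNCaP cells (Homo sapiens) for antiproliferative activity, read by propidium iodide staining, with a stated time of 96 h (a higher number here means a weaker inhibitor, a lower number a stronger inhibitor), compound 1 (`CC(O)(CSc1ccccc1C(F)(F)F)C(=O)Nc1ccc(S(F)(F)(F)(F)F)cc1`) gives 12300 nM and compound 2 (`CC(O)(COc1cccc(S(F)(F)(F)(F)F)c1)C(=O)Nc1ccc(C(F)(F)F)cc1`) gives 12800 nM as its value. Compound 3 (`CC1(C)C(=O)N(c2ccc(S(F)(F)(F)(F)F)cc2)C(=S)N1c1ccc(C(F)(F)F)cc1`) gives 47400 nM as the highest of the three numbers, and it is the weakest, beyond the scatter from both others. Compound 4 (`CC1(C)C(=O)N(c2ccc(S(F)(F)(F)(F)F)cc2)C(=S)N1c1cccc(C(F)(F)F)c1`) has 3-(trifluoromethyl)phenyl in place of 4-(trifluoromethyl)phenyl on an amide-type nitrogen in a ring with the rest of compound 3 unchanged. Among the compounds with values here, no measured pair shows such a change, so the expectation starts from compound 3 at 47400 nM and foresees no step beyond the scatter in this assay here. The expected step (a 1.2-fold lower number from compound 3 to compound 4 (0.07 log units; within the scatter)) is small. Compound 4 is therefore estimated to read 40000 nM (expected range 15000 nM to 100000 nM).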

Compound 4, half-maximal inhibitory concentration: 8800 nM
Beside the measured number, compound 4's estimate is 4.5-fold (0.66 log units) above it; measured number below the stated range.
By their numbers in this assay, from the lowest: compounds 4, 1 and 2 (each within the scatter of the next); then compound 3.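

In this assay, the place of the trifluoromethyl group on the phenyl ring at the amide-type nitrogen matters: with the same atoms joined differently, there is a 5.4-fold lower number from compound 3 to compound 4 (0.73 log units; beyond the scatter) on going to 3-(trifluoromethyl)phenyl. Within the data shown here, the earlier compounds held no pair differing in one place, so this is the first step that can be read at this position. Nothing measured here offers a reason for the step.

As far as these compounds go, whether a nitrile or a carboxylic acid in place of the trifluoromethyl group would read differently at this position stays open, as does whether the same move holds on the core of compound 1.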